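This account rests on a few compounds, and the source may have more. Where it says the series, first, only, none or still open, it means among the compounds named here.

Measured so far:
compound 1 `COC(=O)CC/C(C)=C/Cc1c(OC)c(C)c2c(c1OCC#CCN1CCCc3ccccc31)C(=O)OC2` — 9570 nM
compound 2 `COC(=O)CC/C(C)=C/Cc1c(OC)c(C)c2c(c1OCC#CCN1CCN(c3ccc(C#N)cc3)CC1)C(=O)OC2` — 37800 nM
compound 3 `CCCCNc1ccc(CC#CCOc2c(C/C=C(\C)CCC(=O)OC)c(OC)c(C)c3c2C(=O)OC3)cc1` — 5960 nM

In a functional assay on SH-SY5Y cells (Homo sapiens) for inhibition, read by sulforhodamine B assay (a lower number here means a stronger inhibitor, a higher number a weaker inhibitor), compound 2 gives the highest number of the three; compound 1 and compound 3 both sit well below it, beyond the scatter. Compound 4 `COC(=O)CC/C(C)=C/Cc1c(OC)c(C)c2c(c1OCC#CCN1CCN(Cc3ccc(Cl)cc3)CC1)C(=O)OC2` is not yet measured. It differs from compound 2 by 4-chlorobenzyl in place of 4-cyanophenyl on an amine nitrogen in a ring.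

Among the measured compounds shown here, the only measured step, a 1.6-fold lower number from compound 1 to compound 3 (0.21 log units; within the scatter), changes a different part of the amine-bearing chain and does not touch a ring nitrogen substituent, so no step bears directly on this change. For the measured compounds named here, the scale of that step, within the scatter, is the only guide to how much amine variation moves the number. A step of a 1.9-fold lower number from compound 2 to compound 4 (0.28 log units; within the scatter) is therefore expected, toward a lower number but uncertain in size. Compound 4 is estimated at 20000 nM, with a range of 7000 nM to 60000 nM.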

Compound 4, half-maximal inhibitory concentration: 31200 nM
For compound 4 the middle estimate is 1.6-fold (0.19 log units) below the measured one; the measured number falls inside the stated range.
By their numbers in this assay, from the lowest: compounds 3 and 1 (each within the scatter of the next); then compounds 4 and 2 (each within the scatter of the next).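

In this assay, 4-chlorobenzyl in place of 4-cyanophenyl on the ring amine nitrogen gives a 1.2-fold lower number from compound 2 to compound 4 (0.08 log units; within the scatter), so this pair cannot be told apart. Among the compounds shown here, this is the first reading at this position: with the same heavy-atom count, exchanging the nitrile, and its hydrogen-bond acceptor, for chlorine on a benzyl group leaves the number within the scatter. No measurement available here accounts for this result. Still open, on these data alone, is whether an amide on that ring nitrogen, or a longer chain leading to the aromatic ring, would move the number beyond the scatter.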